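The source may report more compounds than this note shows. Statements on the series, on what has been measured and on what is new or still open speak of the compounds shown alone.

Compound 1 `CCCCn1c(-c2ccc(OC)cc2)cnc1NC(=O)c1ccc(F)cc1`: > 100000 nM
Compound 2 `Cc1ccccc1-c1cnc(NC(=O)c2ccc(F)cc2)n1C`: > 50000 nM
Compound 3 `COc1cccc(-c2cnc(NC(=O)c3ccc(F)cc3)n2C)c1`: > 100000 nM

Of the compounds shown here, three have been measured in a toxicity assay on THP-1 cells (Homo sapiens) for inhibition; on this read-out lower numbers stand for higher toxicity in this test and higher numbers for lower toxicity in this test. Compound 1 gives > 100000 nM there, which is a limit of the assay and not a number. Compound 2 gives > 50000 nM, also a limit. Compound 3 gives > 100000 nM, again a limit. Compound 1 thus sits at the limit of > 100000 nM in this assay, at which 2 of the 3 values shown sit, shared with compound 3, while compound 2 sits at the limit of > 50000 nM in this assay, at which 1 of the 3 values shown sits. Among the compounds with values here, the only one-place step among them, a step that the two limits leave unreadable from compound 2 to compound 3, is unreadable because of the limits. Compound 4 `COc1ccc(-c2cnc(NC(=O)c3ccc(F)cc3)n2C(C)C)cc1` differs from compound 1 by isopropyl in place of butyl on an aromatic nitrogen. Within the data shown here, no measured step bears on this change, so no shift beyond the scatter is expected; the change is estimated to amount to a number no higher from compound 1 to compound 4 (the limit leaves the size open). Compound 4 is therefore expected to give 100000 nM in this assay, between 50000 nM and 200000 nM, most likely reported again only as a limit.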

Compound 4, half-maximal cytotoxic concentration: > 50000 nM
Compound 4: a limit, no number; the forecaster's own chance of this, stated with the estimate: 85%; the middle value does not contradict the limit.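

Within the data shown here, compound 1 and compound 4 are both reported only as limits in this assay, so no step between them can be read. The compounds shown leave open what concentration, if any, would produce a half-maximal cytotoxic effect for any of them.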